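Ester chain length in the shared dihydropyridine-type series

The source may report more compounds than this note shows. Statements on the series, on what has been measured and on what is new or still open speak of the compounds shown alone.

Compound 1 `COC(=O)C1=C(C)NC(C)=C(C(=O)OCCCc2ccccc2)C1c1cnc(SC)n1Nc1ccccc1`: 3.05 nM
Compound 2 `CSc1ncc(C2C(C(=O)OCc3ccccc3)=C(C)NC(C)=C2C(=O)OC(C)C)n1Nc1ccccc1`: 7.24 nM

Of the compounds shown here, two have been measured in an assay on isolated protein (strain albino) for antagonist activity at Voltage-dependent L-type calcium channel subunit alpha-1C (Cavia porcellus); on this read-out higher numbers stand for weaker inhibition and lower numbers for stronger inhibition. Compound 1 gives 3.05 nM, and compound 2 gives 7.24 nM. Compound 2 thus has the higher of the two numbers; the gap to compound 1 lies beyond the usual scatter. Among the measured compounds shown here, no single-point step between compound 1 and compound 2 exists, as the two differ at both ester groups, so only their two values can be compared.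

Compound 3 `CSc1ncc(C2C(C(=O)OCCCc3ccccc3)=C(C)NC(C)=C2C(=O)OC(C)C)n1Nc1ccccc1` is not yet measured. It differs from compound 2 by phenethyl in place of phenyl on a saturated chain carbon bound to an oxygen next to a carbonyl group, so that the benzyl ester of compound 2 becomes the 3-phenylpropyl ester already present in compound 1.

Compound 3 is expected to show a step of a 1.6-fold lower number from compound 2 to compound 3 (0.21 log units; within the scatter), a modest lowering that may not clear the scatter. The estimate for compound 3 in this assay is 4.5 nM with a range from 1.5 nM to 13 nM.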

Compound 3, half-maximal inhibitory concentration: 6.22 nM
Compound 3: middle estimate off by 1.4-fold (0.14 log units), on the low side; low and high end bracket the measured number.
By their numbers in this assay, from the lowest: compound 1; then compounds 3 and 2 (each within the scatter of the next).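

Phenethyl in place of phenyl on a saturated chain carbon bound to an oxygen next to a carbonyl group gives a 1.2-fold lower number from compound 2 to compound 3 (0.07 log units; within the scatter), so in this assay the benzyl and 3-phenylpropyl esters are not told apart when the other ester is isopropyl. Among the compounds shown here, the first single-place reading at that other ester comes with the 3-phenylpropyl ester held fixed: isopropyl in place of methyl on an oxygen next to a carbonyl group gives a 2.0-fold higher number from compound 1 to compound 3 (0.31 log units; beyond the scatter), a modest step. No supporting measurement offers an explanation for either step.

Open, from the compounds shown here alone, is whether the isopropyl-for-methyl step keeps its size with the benzyl ester in place. Also open, going by these compounds, is how a longer chain than 3-phenylpropyl, or an amine or carboxylic acid on that chain, would read.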